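Methoxy for Methyl on the Pendant Ring

The compounds below may be only part of what the source reports. "The series", "measured", "known", "first", "only" and "open" are said of these compounds alone.

Three compounds share one core and differ only in the group carried on a pendant ring. In an ADME assay on Huh-5-2 cells (Homo sapiens) for cytotoxicity, read by WST assay, with a stated time of 3 days (a lower number here means that less compound is tolerated, a higher number that more compound is tolerated), compound 1 `Cc1cccc(COc2c(-c3ccccc3)oc3cc(O)cc(O)c3c2=O)c1` gives 29000 nM, compound 2 `COc1cccc(COc2c(-c3ccccc3)oc3cc(O)cc(O)c3c2=O)c1` gives 28000 nM, and compound 3 `Cc1ccc(COc2c(-c3ccccc3)oc3cc(O)cc(O)c3c2=O)cc1` gives 40000 nM. Compound 2 arises from compound 1 by methoxy in place of methyl on an aromatic carbon, and that step was a 1.0-fold lower number from compound 1 to compound 2 (0.02 log units; within the scatter). Compound 3 differs from compound 1 by 4-methylphenyl in place of 3-methylphenyl on a saturated chain carbon bound to an oxygen on an aromatic ring. Compound 4 `COc1ccc(COc2c(-c3ccccc3)oc3cc(O)cc(O)c3c2=O)cc1` has not yet been measured; it arises from compound 3 by methoxy in place of methyl on an aromatic carbon. Going by the values given here, this is the same kind of change as the one from compound 1 to compound 2, but there the entering group sits meta to a large group, whereas in compound 4 it sits para to a large group. Because the earlier step was a 1.0-fold lower number from compound 1 to compound 2 (0.02 log units; within the scatter), a similarly small step is expected here, a 1.1-fold lower number from compound 3 to compound 4 (0.02 log units; within the scatter). Compound 4 is therefore expected to give about 38000 nM in this assay, most likely between 20000 nM and 70000 nM.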

Compound 4, half-maximal cytotoxic concentration: 57000 nM
The estimate for compound 4 lay 1.5-fold (0.18 log units) below the measured number; low and high end bracket the measured number.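

In this assay, methoxy in place of methyl gave a 1.4-fold higher number from compound 3 to compound 4 (0.15 log units; within the scatter), and this step does not differ meaningfully from the earlier one: the same change on two cores in this assay, a 1.0-fold lower number (0.02 log units; within the scatter) from compound 1 to compound 2 and a 1.4-fold higher number (0.15 log units; within the scatter) from compound 3 to compound 4, 1.5-fold (0.17 log units) apart, within the scatter of two such steps. The change therefore carries from one core to the other without a detectable difference, but two pairs cannot show that this would hold on further cores, and neither step is large enough to show that the change has any real effect. Of the other two steps, a 2.0-fold higher number from compound 2 to compound 4 (0.31 log units; beyond the scatter) lies modestly beyond the scatter, while a 2.0-fold higher number from compound 1 to compound 4 (0.29 log units; within the scatter) lies within it.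

The compounds shown leave open what an amine, a carboxylic acid or a longer chain in the same place on the pendant ring would do to tolerated concentration.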